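Amide for Ester at the Enone Carbon of a Macrocycle

The compounds below may be only part of what the source reports. "The series", "measured", "known", "first", "only" and "open" are said of these compounds alone.

Two members of a macrocyclic series have been measured in a functional assay on A549 cells (Homo sapiens) for antiproliferative activity, read by MTT assay, with a stated time of 48 h; on this read-out lower numbers stand for stronger inhibition and higher numbers for weaker inhibition. Compound 1 `CC(=O)OC/C1=C/C[C@](C)(CCC=C(C)C)/C=C/[C@@H](OC(=O)C=C(C)C)[C@](C)(O)/C=C/C1=O` stands lowest of the two numbers; in this assay compound 1 gives 2950 nM. Compound 2 `CC(C)=CCC[C@]1(C)/C=C/[C@@H](OC(=O)C=C(C)C)[C@](C)(O)/C=C/C(=O)/C(C[Si](c2ccccc2)(c2ccccc2)C(C)(C)C)=C\C1` carries a silyl-bearing substituent and, in this assay, compound 2 gives 13000 nM, a gap from compound 1 that lies beyond the scatter. The two compounds differ in more than one place, so the gap cannot be tied to a single change.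

Compound 3 `CC(C)=CCC[C@]1(C)/C=C/[C@@H](OC(=O)C=C(C)C)[C@](C)(O)/C=C/C(=O)/C(C(=O)N(C)C)=C\C1` has not yet been measured. It is reached from compound 1 by a single substitution: dimethylcarbamoyl in place of acetoxymethyl on a double-bonded ring carbon. The acetoxymethyl and dimethylcarbamoyl groups match in heavy-atom count, and the count of hydrogen-bond acceptors falls by one.

For the measured compounds named here, nothing among the measured pairs isolates this particular exchange, so the direction of the step is open. The step of a 1.4-fold higher number from compound 1 to compound 3 (0.13 log units; within the scatter) is expected to stay close to the scatter, with a slight lean toward a higher number. Compound 3 is therefore estimated at 4000 nM, within a range from 1000 nM to 16000 nM.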

Compound 3, half-maximal inhibitory concentration: 2700 nM
For compound 3 the middle estimate is 1.5-fold (0.17 log units) above the measured one; the measured number falls inside the stated range.
By their numbers in this assay, from the lowest: compounds 3 and 1 (each within the scatter of the next); then compound 2.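

In this assay, for the compounds shown here, the exchange of acetoxymethyl for dimethylcarbamoyl on the double-bonded ring carbon gives a 1.1-fold lower number from compound 1 to compound 3 (0.04 log units; within the scatter), the first step that isolates a change in one place. At this ring carbon, therefore, dimethylcarbamoyl, with the same heavy-atom count and one hydrogen-bond acceptor fewer, reads the same as acetoxymethyl within the scatter, and the ester linkage of acetoxymethyl is not required to keep the number at this level in this read-out. No measured evidence is available that bears on why the two groups read alike.

The compounds shown leave open how a carboxylic acid, an amine or an unsubstituted amide on this same ring carbon would read, and whether longer chains on the amide nitrogen, such as ethyl or propyl in place of methyl, would stay as close to compound 1. They also leave open whether compound 1 and compound 3 would stay this close on any cell line or read-out other than this assay.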